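Series notes: aminomethyl for methoxycarbonyl, compound 4

The source may report more compounds than this note shows. Statements on the series, on what has been measured and on what is new or still open speak of the compounds shown alone.

Measured so far:
compound 1, `CCCC[S+]([O-])c1sc2nc(-c3nccs3)cc(-c3ccc(C(=O)OC)cc3)c2c1N` — 15.1 nM
compound 2, `CCCC[S+]([O-])c1sc2nc(-c3ccccc3)nc(-c3ccccc3)c2c1N` — 4.9 nM
compound 3, `CCOC(=O)c1sc2nc(-c3cccs3)cc(-c3ccccc3)c2c1N` — a limit, > 7500 nM

Of the compounds shown here, three share the core of compound 1 and have been read in an assay for inhibition of 15-hydroxyprostaglandin dehydrogenase [NAD(+)] (Homo sapiens), read by fluorescence, with a stated time of 15 min, in the presence of a further agent that is not named here; a higher number here means a weaker inhibitor, a lower number a stronger inhibitor. Of the two numbers in hand, compound 1 has the higher one, 15.1 nM, and compound 2, with 4.9 nM, sits lower by a gap that is beyond the usual scatter of this assay. Compound 3 gives only a limit in this assay, > 7500 nM, and so adds no number to the comparison (the limit of > 7500 nM in this assay, at which 1 of the 3 values shown sits). No two of the measured compounds differ in a single place, so none of these gaps can be tied to one change.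

Compound 4, `CCCC[S+]([O-])c1sc2nc(-c3nccs3)cc(-c3ccc(CN)cc3)c2c1N`, is the next candidate. It differs from compound 1 in one place: aminomethyl in place of methoxycarbonyl on an aromatic carbon. The surviving pair of numbers offers no guide to this particular change, and the step from compound 1 to compound 4 in this assay is therefore expected to stay within or close to the scatter, in either direction, as a 1.3-fold higher number from compound 1 to compound 4 (0.12 log units; within the scatter). Compound 4 is thus estimated at 20 nM in this assay, with a range from 6 nM to 70 nM.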

Compound 4, half-maximal inhibitory concentration: 11.5 nM
For compound 4 the middle estimate is 1.7-fold (0.24 log units) above the measured one; the measured number falls inside the stated range.
By their numbers in this assay, from the lowest: compound 2; then compounds 4 and 1 (each within the scatter of the next). At a limit, above all of these: compound 3.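

Within this assay the exchange of 4-(methoxycarbonyl)phenyl for 4-(aminomethyl)phenyl gives a 1.3-fold lower number from compound 1 to compound 4 (0.12 log units; within the scatter), and this is the first step in the series that can be tied to a single change. The position, on an aromatic carbon of a six-membered aromatic ring of carbon only and para to a large group, therefore accepts both groups without a difference that can be read in this assay, although aminomethyl has fewer heavy atoms than methoxycarbonyl and brings a hydrogen-bond donor that methoxycarbonyl lacks. Nothing in the data at hand bears on why the two groups read alike.

As far as these compounds go, with only these two groups compared here, it remains open whether the position would stay as accepting of a carboxylic acid, a tertiary amine such as dimethylaminomethyl, or a longer chain such as aminoethyl. From the compounds shown here alone, it is also open whether the same exchange would give a similar step on a compound that differs elsewhere on the shared core, as compound 2 and compound 3 do.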